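A few compounds are considered here, and "the series" means these few. Any claim that something is new, unique, unknown or untested is made for them only; others in the source may bear on it.

Measured so far in an ADME assay on HepG2 cells (Homo sapiens) for cytotoxicity, read by MTT assay, with a stated time of 48 h; a lower number here means that less compound is tolerated, a higher number that more compound is tolerated:
- compound 1 `CC(=O)OC[C@H]1O[C@H](OC[C@H](Cn2cc(-c3ccc(-c4noc(NC5CCCCC5)n4)cc3)nn2)OC(C)=O)C=C[C@@H]1OC(C)=O`: 79.8 ug/mL
- compound 2 `CC(=O)OC[C@H]1O[C@H](OC[C@@H](Cn2cc(CN(c3nc(-c4ccc(Cl)cc4)no3)C3CCCCC3)nn2)OC(C)=O)C=C[C@@H]1OC(C)=O`: 46.9 ug/mL
- compound 3 `C#CCN(c1nc(-c2cccc([N+](=O)[O-])c2)no1)C1CCCCC1`: 45.5 ug/mL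

Compound 2 sits at the second highest of the three numbers. Compound 3 gives a reading next to it, within the scatter, and compound 1 gives the furthest reading, also within the scatter, so the three measured compounds do not separate from one another in this assay.

Compound 4 `CC(=O)OC[C@H]1O[C@H](OC[C@@H](Cn2cc(CN(c3nc(-c4ccc(C)cc4)no3)C3CCCCC3)nn2)OC(C)=O)C=C[C@@H]1OC(C)=O` is not yet measured. It differs from compound 2 in one place: methyl in place of chloro on an aromatic carbon. Both groups have the same heavy-atom count, neither adds a ring, a donor or an acceptor, and the rest of the structure, including the sugar-bearing chain and the cyclohexyl-bearing core, is unchanged.

Within the data shown here, no step between measured compounds has been worked out, so there is nothing that shows what this exchange does. The expectation for compound 4 is a step of a 1.0-fold higher number from compound 2 to compound 4 (0.01 log units; within the scatter) of no size beyond the scatter, in no set direction. Compound 4 is estimated at 48 ug/mL, in the range 24 ug/mL to 96 ug/mL.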

Compound 4, half-maximal cytotoxic concentration: 36.8 ug/mL
Compound 4: the middle estimate sits 1.3-fold (0.12 log units) above what was measured; low and high end bracket the measured number.
By their numbers in this assay, from the lowest: compounds 4, 3, 2 and 1 (each within the scatter of the next, the first and the last beyond it).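

In this assay, among these compounds, the exchange of chloro for methyl on the aromatic carbon para to a large group gives a 1.3-fold lower number from compound 2 to compound 4 (0.11 log units; within the scatter) and is the only one-place step so far. This step stays within the scatter, so the 4-chlorophenyl and 4-methylphenyl groups are not told apart at this position in this assay, with the sugar-bearing chain and cyclohexyl-bearing core held constant. Nothing available bears on the reason for this result.

As far as these compounds go, whether a methoxy group, an amine or a carboxylic acid on this aromatic carbon would give a step beyond the scatter remains open. Also open, from the compounds shown here alone, is whether the exchange of chloro for methyl would read the same on a different parent structure.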